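Propoxy in Place of Methylsulfanyl on a Shared Core

The source may report more compounds than this note shows. Statements on the series, on what has been measured and on what is new or still open speak of the compounds shown alone.

In a functional assay (spleen, spleen) for activation, with Mus musculus as the target (on this read-out higher numbers stand for an effect only at larger amounts of compound and lower numbers for an effect already at smaller amounts), compound 1 `CCCCOc1nc(N)c2[nH]c(=O)n(Cc3ccccc3)c2n1` gives 0.001 uM. Compound 2 `CSc1nc(N)c2nc(O)n(Cc3ccccc3)c2n1` gives 0.1 uM, the higher of the two numbers, a gap well beyond the usual scatter. Compound 3 `CCCOc1nc(N)c2nc(O)n(Cc3ccccc3)c2n1` has not yet been measured in this assay. It differs from compound 2 by propoxy in place of methylsulfanyl on an aromatic carbon. For the measured compounds named here, no step between measured compounds covers this change alone. Because compound 1 gives 0.001 uM, compound 3 is expected to move toward that lower number, with a drop beyond the scatter. The estimate for compound 3 is 0.003 uM, within 0.0005 uM to 0.03 uM. The expected step is a 33-fold lower number from compound 2 to compound 3 (1.52 log units; beyond the scatter).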

Compound 3, minimum effective concentration: 0.01 uM
Compound 3: middle estimate off by 3.3-fold (0.52 log units), on the low side, and the stated range covers the measured number.
By their numbers in this assay, from the lowest: compound 1; then compound 3; then compound 2.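

This position, an aromatic carbon between two ring nitrogen atoms, is sensitive to the group it carries: in this assay propoxy in place of methylsulfanyl gives a 10-fold lower number from compound 2 to compound 3 (1.00 log units; beyond the scatter) with no other change to the shared core. The swap replaces sulfur with oxygen and lengthens the chain at once, so the step cannot be assigned to either change alone. No measured evidence here explains the step.

Methoxy, with oxygen on a short chain, and propylsulfanyl, with sulfur on a longer chain, could separate the two changes. As far as these compounds go, how an amine at this position would behave also remains open.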